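This account rests on a few compounds, and the source may have more. Where it says the series, first, only, none or still open, it means among the compounds named here.

Measured compounds, in an assay on Sf21 cells for inhibition of high affinity nerve growth factor receptor (Homo sapiens), read by HTRF, with a stated time of 30 min, in the presence of a further agent that is not named here; on this read-out higher numbers stand for weaker inhibition and lower numbers for stronger inhibition:

- compound 1, `CC1(C)c2[nH]nc(NC(=O)c3ccccc3)c2CN1Cc1ccc(F)cc1`, gives 1180 nM
- compound 2, `CC1(C)c2[nH]nc(NC(=O)c3ccccc3)c2CN1Cc1cccc(F)c1F`, gives 200 nM
- compound 3, `CC1(C)c2[nH]nc(NC(=O)c3ccccc3)c2CN1Cc1cc(F)ccc1F`, gives 480 nM

All three share the core and the benzamide; they differ only in the fluorophenyl on the saturated chain carbon bound to the amine nitrogen in the ring. Compound 2 stands lowest of the three: the steps are a 5.9-fold lower number from compound 1 to compound 2 (0.77 log units; beyond the scatter) and a 2.4-fold higher number from compound 2 to compound 3 (0.38 log units; beyond the scatter), with a 2.5-fold lower number from compound 1 to compound 3 (0.39 log units; beyond the scatter) as the third. Compound 4, `CN1CCN(c2ccc(C(=O)Nc3n[nH]c4c3CN(Cc3cccc(F)c3F)C4(C)C)cc2)CC1`, keeps the 2,3-difluorophenyl of compound 2 and changes the benzamide instead: 4-methylpiperazin-1-yl in place of hydrogen on an aromatic carbon. Within the data shown here, none of the measured steps touches that ring, so no measured step bears directly on this change and nothing here indicates its direction. The working expectation is therefore a step of no change at the digits printed from compound 2 to compound 4 (within the scatter) in this assay, that is, nothing beyond the scatter, with a wide margin either way. For compound 4 the estimate in this assay is 200 nM, with a range of 50 nM to 800 nM.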

Compound 4, half-maximal inhibitory concentration: 17 nM
Compound 4: the middle estimate sits 12-fold (1.07 log units) above what was measured; the whole stated range lies above it.
By their numbers in this assay, from the lowest: compound 4; then compound 2; then compound 3; then compound 1.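

In this assay, the benzamide ring proves to be a productive place for change: with the 2,3-difluorophenyl held fixed, 4-methylpiperazin-1-yl in place of hydrogen gives a 12-fold lower number from compound 2 to compound 4 (1.07 log units; beyond the scatter). That single step exceeds the largest change among the fluorophenyl variants, a 5.9-fold lower number from compound 1 to compound 2 (0.77 log units; beyond the scatter), so this aromatic carbon, para to a large group, accepts a six-membered non-aromatic ring with a clear gain in this read-out. Nothing available explains why the number falls.

Only this one substituent is shown at this position, so it remains open which part of it carries the step; a piperazin-1-yl without the methyl, a morpholin-4-yl or a dimethylamino group would begin to separate those parts. Also open, from the compounds shown here alone, is whether the step carries over to the 2,5-difluorophenyl of compound 3 or the 4-fluorophenyl of compound 1.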